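This account rests on a few compounds, and the source may have more. Where it says the series, first, only, none or still open, it means among the compounds named here.

Compound 1 `COc1cccc(Oc2c(NS(=O)(=O)c3ccc(C(C)(C)C)cc3)ncnc2OCCOc2ncccn2)c1` and compound 2 `COc1cccc(Oc2c(NS(=O)(=O)c3ccc(C(C)(C)C)cc3)ncnc2OCCOc2ncc(C)cn2)c1` share one core; in an assay on cells (Endothelial cell) for binding affinity to Endothelin-1 receptor (Sus scrofa) (a higher number here means a weaker inhibitor, a lower number a stronger inhibitor), compound 1 gives 1.9 nM and compound 2 gives 0.86 nM. The change between them is methyl in place of hydrogen on an aromatic carbon and it made the step of a 2.2-fold lower number from compound 1 to compound 2 (0.34 log units; beyond the scatter). Compound 3 `CSc1cnc(OCCOc2ncnc(NS(=O)(=O)c3ccc(C(C)(C)C)cc3)c2-c2cccs2)nc1` has a different core; the difference between the two cores is not broken down here. In this assay compound 3 gives 0.89 nM. Compound 4 `CSc1cnc(OCCOc2ncnc(NS(=O)(=O)c3ccc(C(C)(C)C)cc3)c2-c2ccc(C)s2)nc1` is not yet measured; from compound 3 it differs by methyl in place of hydrogen on an aromatic carbon. This is the same kind of change as before, but the surroundings differ: earlier the methyl entered on a six-membered aromatic ring with 2 nitrogen, two atoms from the ring nitrogen, para to a large group, whereas here it enters on a five-membered aromatic ring with 1 sulfur, next to the ring sulfur, two ring bonds from the ring atom that bears a large group. Resting on the earlier step of a 2.2-fold lower number from compound 1 to compound 2 (0.34 log units; beyond the scatter), compound 4 is expected to show a step of a 1.5-fold lower number from compound 3 to compound 4 (0.17 log units; within the scatter), a similarly modest change. The estimate for compound 4 is 0.6 nM, with a likely range from 0.3 nM to 1.5 nM.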

Compound 4, half-maximal inhibitory concentration: 0.16 nM
The estimate for compound 4 lay 3.8-fold (0.57 log units) above the measured number, outside the stated range (below it).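

Replacing thiophen-2-yl with 5-methylthiophen-2-yl gives a 5.6-fold lower number from compound 3 to compound 4 (0.75 log units; beyond the scatter) in this assay, so adding a methyl lowers the number on both cores, although it enters a different ring on each. The two steps point the same way, and their sizes cannot be told apart: the same change on two cores in this assay, a 2.2-fold lower number (0.34 log units; beyond the scatter) from compound 1 to compound 2 and a 5.6-fold lower number (0.75 log units; beyond the scatter) from compound 3 to compound 4, 2.5-fold (0.40 log units) apart, within the scatter of two such steps This shows that the direction of the change carried over between these two cores, but it does not show that the methyl works better on one core than on the other, and two pairs make no general rule.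

The compounds shown leave open whether an ethyl group or a chlorine atom on that same aromatic carbon would lower the number further. They also leave open how a longer chain there would behave.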